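The source may report more compounds than this note shows. Statements on the series, on what has been measured and on what is new or still open speak of the compounds shown alone.

Measured so far:
Compound 1, `CCCOc1cc([C@](O)(CCN(C)C)[C@@H](c2cc3cc(Br)ccc3nc2OC)c2ccnc(OC)c2OC)cc(OC)n1`: 6.5 uL/min
Compound 2, `COc1cccc([C@H](c2cc3cc(Br)ccc3nc2OC)[C@@](O)(CCN(C)C)c2cc(SC)nc(SC)c2)c1F`: 17 uL/min

In an ADME assay on microsomes from liver (Mus musculus) for metabolic stability (a lower number here means slower removal, a higher number faster removal of the compound), compound 2 gives the higher of the two numbers, while compound 1 gives 6.5 uL/min, a gap that lies beyond the usual scatter of this kind of measurement. Compound 3, `COc1nc2ccc(Br)cc2cc1[C@@H](c1ccnc(OC)c1OC)[C@@](O)(CCN(C)C)c1cc(SC)nc(SC)c1`, has not yet been measured. It differs from compound 2 in one place: 2,3-dimethoxypyridin-4-yl in place of 2-fluoro-3-methoxyphenyl on a saturated chain carbon bound to an aromatic carbon and a saturated chain carbon. Within the data shown here, the group that enters is one that compound 1 also carries, though compound 1 differs from compound 2 elsewhere as well, so no step resting on a single change is known. The shared core is kept throughout. The step of a 1.4-fold lower number from compound 2 to compound 3 (0.15 log units; within the scatter) is expected to be modest and downward, but it could also fall within the scatter. Compound 3 is expected to give 12 uL/min in this assay, with a range from 5 uL/min to 28 uL/min.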

Compound 3, intrinsic clearance in a liver preparation (reported as CLH), per the amount of preparation that the assay uses: 10 uL/min
Compound 3: the middle estimate sits 1.2-fold (0.08 log units) above what was measured; measured number inside the range.
By their numbers in this assay, from the lowest: compounds 1, 3 and 2 (each within the scatter of the next, the first and the last beyond it).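

In this assay, among these compounds, placing 2,3-dimethoxypyridin-4-yl instead of 2-fluoro-3-methoxyphenyl on this saturated chain carbon gives the first single-change comparison at this position (a 1.7-fold lower number from compound 2 to compound 3 (0.23 log units; within the scatter)), so adding a ring nitrogen and a second methoxy group does not move the number past the usual scatter. The second single change, a group of 10 heavy atoms with 2 sulfur atoms in place of a group of 12 heavy atoms with 2 oxygen atoms, also stays within the scatter (a 1.5-fold higher number from compound 1 to compound 3 (0.19 log units; within the scatter)). Nothing measured here gives a reason for these numbers.

On these data alone, it remains open whether a plain phenyl or a pyridine bearing an amine on this carbon would give a clearly different number. Also open, as far as these compounds go, is whether 2-fluoro-3-methoxyphenyl would behave the same way alongside the group that compound 1 carries.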